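Piperidine Amides Tested for Cytotoxicity on Prostate Cancer Cells

This account rests on a few compounds, and the source may have more. Where it says the series, first, only, none or still open, it means among the compounds named here.

Measured compounds:
compound 1, `CC(C)(C)OC(=O)c1cccc(NC(=O)C2CCCN(C(=O)c3cc(C(F)(F)F)cc(C(F)(F)F)c3)C2)c1`, 0%
compound 2, `Cc1nc(-c2cccc(C(=O)N3CCCC(C(=O)Nc4ccc(Cl)cc4)C3)c2)no1`, 0%

Two amides built on a shared piperidine core have been examined in an ADME assay on PC-3 cells (Homo sapiens) for cytotoxicity, read by WST assay, tested at 100 uM; on this read-out higher numbers stand for more inhibition at the one concentration tested (going by the name of the read-out) and lower numbers for less inhibition. Compound 1 carries a tert-butyl ester on one anilide and a bis(trifluoromethyl)benzoyl group on the ring nitrogen, and in this assay compound 1 gives 0%. Compound 2 bears a chloroanilide and a benzoyl group substituted with 5-methyl-1,2,4-oxadiazol-3-yl, and in this assay compound 2 gives 0%. Compound 2 thus stands level with compound 1 at the digits shown, with no difference beyond the scatter between the two.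

The next compound, compound 3 `O=C(Nc1ccc(Cl)cc1)C1CCCN(C(=O)c2cccc(-c3cccs3)c2)C1`, keeps the chloroanilide and the benzoyl group of compound 2 but differs by thiophen-2-yl in place of 5-methyl-1,2,4-oxadiazol-3-yl on an aromatic carbon. For the measured compounds named here, no measured pair shows the effect of such a change, and both measured compounds sit at the bottom of the read-out. Compound 3 is therefore expected to stay near the floor, with a step from compound 2 of about a number 3 percentage points higher from compound 2 to compound 3 (within the scatter), which is none beyond the scatter. Compound 3 is estimated at 3%, with a range from 0% to 20%.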

Compound 3, a percentage reported as inhibition, at one concentration (the size of the read-out at that concentration, not a potency): 4%
For compound 3 the middle estimate is 1 percentage points below the measured one; measured number inside the range.
By their numbers in this assay, from the lowest: compounds 1, 2 and 3 (each within the scatter of the next).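

For the compounds shown here, compounds 2 and 3 are the first pair that differ in one place, and thiophen-2-yl in place of 5-methyl-1,2,4-oxadiazol-3-yl on an aromatic carbon, meta to a large group, gives in this assay a step of a number 4 percentage points higher from compound 2 to compound 3 (within the scatter) on the shared core. At this position, then, a five-membered aromatic ring with 3 hetero atoms and 3 hydrogen-bond acceptors can give way to one with 1 hetero atom and 1 hydrogen-bond acceptor without a step beyond the scatter, although both compounds lie near the bottom of the read-out, where little can be told apart. Nothing at hand accounts for the size of this step.

The compounds shown leave open whether any group at this position, such as an amine or a carboxylic acid in place of the five-membered aromatic ring, would move the read-out beyond the scatter. They also leave open what the chloroanilide contributes on its own: compound 1 differs from compound 2 in more than one place, and its tert-butyl ester and bis(trifluoromethyl)benzoyl group cannot be separated.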